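The source may hold more compounds than are shown below. What is called first, only, known or untested is meant among the compounds shown, and "the series" means these compounds.

Compound 1 `CN(C)[C@H]1CC[C@H](Nc2ncnc3[nH]ccc23)CC1` gives -0.6 in a physicochemical assay for lipophilicity, using the shake flask method, at pH 7.4; on this read-out higher numbers stand for higher lipophilicity and lower numbers for lower lipophilicity.
Compound 2 `CN(C)[C@H]1CC[C@H](Nc2ncnc3ccsc23)CC1` gives -0.2 in this assay.
Compound 3 `CN(C)[C@H]1CC[C@H](Oc2ncnn3ccc([C@H]4CC[C@H](C(N)=O)CC4)c23)CC1` gives 1 in this assay.

Among these three numbers, compound 1 stands lowest. The nearest to it is compound 2, whose number lies higher by a gap beyond the scatter; the furthest is compound 3, whose number lies higher still, also beyond the scatter. None of these pairs differs in a single place, so the gaps between them show only what the two values show and cannot be pinned to one change.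

Compound 4 `CN(C)[C@H]1CC[C@H](Nc2ncnc3[nH]cc([C@H]4CC[C@H](C(N)=O)CC4)c23)CC1` is not yet measured in this assay. It differs from compound 1 in one place: 4-carbamoylcyclohexyl in place of hydrogen on an aromatic carbon. Within the data shown here, no measured pair shows this change by itself. Compound 3 carries the same 4-carbamoylcyclohexyl group, but on a different core and with a different linkage, so its value offers only a loose hint of the direction.

On that basis compound 4 is expected to move upward from compound 1 by a moderate step, a number 0.60 log units higher from compound 1 to compound 4 (beyond the scatter), beyond the scatter. The estimate for compound 4 in this assay is 0, with a range from -0.5 to 0.5.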

Compound 4, distribution coefficient: 0
Compound 4: the middle estimate sits on the measured number at the digits printed; low and high end bracket the measured number.
By their numbers in this assay, from the lowest: compound 1; then compounds 2 and 4 (each within the scatter of the next); then compound 3.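

Among these compounds, until now no two compounds measured in this assay differed in a single place, so no gap could be tied to one change. Among the compounds shown here, the step of a number 0.60 log units higher from compound 1 to compound 4 (beyond the scatter) is the first that can be, and it belongs to 4-carbamoylcyclohexyl in place of hydrogen on an aromatic carbon of the five-membered aromatic ring, two ring bonds from the ring nitrogen. It shows that at this position a group of 9 heavy atoms, with a hydrogen-bond donor and a hydrogen-bond acceptor, moves this read-out upward by only a modest step, though one beyond the scatter, and nothing measured here accounts for the size of that step.

On these data alone, what stays open is whether the step belongs to the whole group or to one part of it: a plain cyclohexyl, a cyclohexyl carrying a carboxylic acid in place of the carbamoyl, or one carrying an amine would separate these. As far as these compounds go, whether the same group would move the read-out by a like step at another carbon of the shared core also stays open, since this single pair is all that shows the change.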